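Carbamate in place of ethyl ether on the shared core

This account rests on a few compounds, and the source may have more. Where it says the series, first, only, none or still open, it means among the compounds named here.

Compound 1 `CC(C)=CCC1Cc2c(O)cc(=O)n(CCCO)c2CC1(C)C` gives 25.6% in a functional assay on PANC-1 cells (Homo sapiens) for inhibition, read by MTT assay, with a stated time of 24 h, tested at 10 uM; on this read-out higher numbers stand for more inhibition at the one concentration tested (going by the name of the read-out) and lower numbers for less inhibition. Compound 2 `CCOc1cc(=O)n(CCCO)c2c1CC(CC=C(C)C)C(C)(C)C2` gives 66.5% in this assay. Compound 3 `COc1ccc(NC(=O)Oc2cc(=O)n(CCCO)c3c2CC(CC=C(C)C)C(C)(C)C3)cc1` gives 3.7% in this assay.

Compound 2 stands highest of the three numbers. The nearest of the others is reached by a number 40.9 percentage points higher from compound 1 to compound 2 (beyond the scatter), the furthest by a number 62.8 percentage points lower from compound 2 to compound 3 (beyond the scatter); both steps lie beyond the scatter.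

Compound 4 `CC(C)=CCC1Cc2c(OC(=O)Nc3ccc(F)cc3F)cc(=O)n(CCCO)c2CC1(C)C` differs from compound 2 in one place: (2,4-difluorophenyl)carbamoyl in place of ethyl on an oxygen on an aromatic ring. For the measured compounds named here, two measured steps bear on this change. The closest is a number 62.8 percentage points lower from compound 2 to compound 3 (beyond the scatter), where the same ethyl gives way to a carbamoyl group carrying a substituted phenyl ring. The other is a number 21.9 percentage points lower from compound 1 to compound 3 (beyond the scatter), which shows that a carbamoyl on this oxygen also sits below the bare hydroxyl. Going by the values given here, on that basis a large downward step in this assay is expected for compound 4, with the fluorinated ring treated as likely to behave like the methoxy ring of compound 3, though no fluorinated analogue has been measured.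

Compound 4 is therefore expected to give about 10% in this assay, within 0% to 35%, which means an estimated step of a number 56.5 percentage points lower from compound 2 to compound 4 (beyond the scatter).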

Compound 4, a percentage reported as inhibition, at one concentration (the size of the read-out at that concentration, not a potency): 69.7%
The estimate for compound 4 lay 59.7 percentage points below the measured number; the measured number lies above the stated range.
By their numbers in this assay, from the lowest: compound 3; then compound 1; then compounds 2 and 4 (each within the scatter of the next).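

A carbamoyl on this oxygen does not in itself go with a low number in this assay: a number 3.2 percentage points higher from compound 2 to compound 4 (within the scatter), so the (2,4-difluorophenyl)carbamoyl group and the ethyl cannot be told apart here, and a number 44.1 percentage points higher from compound 1 to compound 4 (beyond the scatter) shows that this carbamoyl, like the ethyl, sits well clear of the bare hydroxyl. The low number of compound 3 therefore cannot be read as a property of carbamoyl groups as a class, since exchanging only the ring on the amide-type nitrogen, 2,4-difluorophenyl in place of 4-methoxyphenyl, gives a number 66 percentage points higher from compound 3 to compound 4 (beyond the scatter). For the compounds shown here, nothing available explains why this exchange on the nitrogen moves the number so far.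

The compounds shown leave open whether that step follows the loss of the methoxy group or the arrival of the fluorines, which an unsubstituted phenyl or a 4-fluorophenyl on the same carbamoyl would help to separate. They also leave open how a carbamoyl carrying a simple butyl chain instead of a ring would read, and whether compound 2 and compound 4 would stay alike over a range of concentrations.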